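The compounds below may be only part of what the source reports. "The series", "measured", "known", "first", "only" and "open" are said of these compounds alone.

Measured in a functional assay on MOLM-13 cells (Homo sapiens) for antiproliferative activity; a higher number here means a weaker inhibitor, a lower number a stronger inhibitor:
- Compound 1 `Cc1c(-c2ccc(-c3ccccc3F)cc2)nc2ccc(F)cc2c1-c1noc(=O)[nH]1`: > 3000 nM (a limit)
- Compound 2 `Cc1c(-c2ccc(-c3ccccc3F)cc2)nc2ccc(F)cc2c1C(N)=O`: 128 nM

Among the compounds with values here, compound 2, at 128 nM, holds the only actual number in this assay. Compound 1 is recorded at > 3000 nM, which is a limit of the assay. Compound 3 `Cc1c(-c2ccc(-c3ccccc3F)cc2)nc2ccc(F)cc2c1C(=O)NC#N` carries cyano in place of hydrogen on an amide-type nitrogen. Within the data shown here, one measured step bears on this place, an at least 23-fold lower number from compound 1 to compound 2 (1.36 log units; beyond the scatter), and it is large. There, the larger group belongs to compound 1, so a moderate weakening is expected, though with wide uncertainty. The expected change is a 2.3-fold higher number from compound 2 to compound 3 (0.37 log units; beyond the scatter). For compound 3 the estimated value is 300 nM, with an expected range from 30 nM to 3000 nM.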

Compound 3, half-maximal inhibitory concentration: > 3000 nM
Compound 3: no number, only a limit; the forecaster's own chance of this, stated with the estimate: 15%; at least 10-fold (1.00 log units) between middle value and limit.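

In this assay, cyano in place of the amide hydrogen gives an at least 23-fold higher number from compound 2 to compound 3 (1.36 log units; beyond the scatter). The earlier step replaced the whole group on the aromatic carbon, whereas this one shows that a change on the amide-type nitrogen alone, with the carbonyl kept, is enough to lose a measurable number. Compound 3 has no number, only a limit of the assay: the limit of > 3000 nM in this assay, at which 2 of the 3 values shown sit.

The step from compound 1 to compound 3 cannot be read, as both ends are limits. Going by these compounds, whether methyl on this nitrogen, or a carboxylic acid in place of the carbamoyl, would keep a measurable number stays open.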